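Series notes: carbonyl substitution from compound 3 to compound 4

The compounds below may be only part of what the source reports. "The series", "measured", "known", "first", "only" and "open" are said of these compounds alone.

Of the compounds shown here, three sharing one core have been measured in a functional assay on A549 cells (Homo sapiens) for inhibition, read by sulforhodamine B assay, with a stated time of 48 h, tested at 1 uM; on this read-out lower numbers stand for a stronger effect and higher numbers for a weaker effect at the one concentration tested. Compound 3 `COc1cc(Cl)cc(-c2nn(-c3cccc(NC(=O)Nc4ccc(Cl)c(Cl)c4)c3)cc2-c2ccncc2)c1` gives 82%, the highest of the three numbers. Compound 1 `O=C(Nc1cccc(-n2cc(-c3ccncc3)c(-c3cc(O)cc(Cl)c3)n2)c1)Nc1ccc(Cl)c(Cl)c1` gives 75%, and the step of a number 7 percentage points higher from compound 1 to compound 3 (within the scatter) lies within the scatter, so the two are not separated. Compound 2 `COc1cc(Cl)cc(-c2nn(-c3cccc(NC(=O)Nc4ccc(Cl)c(C(F)(F)F)c4)c3)cc2-c2ccncc2)c1` gives 40%; the step of a number 42 percentage points higher from compound 2 to compound 3 (beyond the scatter) is large and beyond the scatter.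

Compound 4 `COc1cc(Cl)cc(-c2nn(-c3cccc(NC(=O)c4cccc(C(F)(F)F)c4)c3)cc2-c2ccncc2)c1` has not been measured. It differs from compound 3 in one place: 3-(trifluoromethyl)phenyl in place of (3,4-dichlorophenyl)amino on a carbonyl carbon. For the measured compounds named here, no measured step alters this carbonyl carbon, so none bears on it directly. Going by the values given here, the only measured change involving a trifluoromethyl is a number 42 percentage points higher from compound 2 to compound 3 (beyond the scatter), where trifluoromethyl in place of chloro on an aromatic carbon went with the lower number; compound 4 also contains a trifluoromethyl, as part of the entering 3-(trifluoromethyl)phenyl, but the (3,4-dichlorophenyl)amino leaves with it, so that step cannot simply be carried over. The expectation therefore rests mainly on the spread of the series. Compound 4 is expected to give 60%, between 30% and 90%. This means an expected step of a number 22 percentage points lower from compound 3 to compound 4 (beyond the scatter), which may fall either side of the scatter.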

Compound 4, a percentage reported as activity, at one concentration (the size of the read-out at that concentration, not a potency): 75%
The estimate for compound 4 lay 15 percentage points below the measured number; the range from low to high includes it.
By their numbers in this assay, from the lowest: compound 2; then compounds 1, 4 and 3 (each within the scatter of the next).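

With the read-out of this assay, the carbonyl carbon accepts an aryl group in place of an arylamino group without a separable change: a number 7 percentage points lower from compound 3 to compound 4 (within the scatter), although the hydrogen-bond donor of the (3,4-dichlorophenyl)amino group leaves with it. The second step, a number 35 percentage points higher from compound 2 to compound 4 (beyond the scatter), shows that a trifluoromethyl in the group on this carbonyl carbon does not by itself go with the low number of compound 2, since compound 4 also carries one and stands well apart from compound 2; among these compounds, that low number is seen only with the (4-chloro-3-(trifluoromethyl)phenyl)amino group. Nothing available on these compounds accounts for either step.

Open, as far as these compounds go, is whether the low number of compound 2 would persist with 4-chloro-3-(trifluoromethyl)phenyl attached directly to the carbonyl carbon, a change that would separate the effect of that substitution pattern from that of the amino nitrogen. Also open, from the compounds shown here alone, is how a non-aromatic group on this carbon, such as a piperidine, or a carboxylic acid on the entering phenyl would read, and whether these single-concentration numbers would hold across a range of concentrations.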